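The source may report more compounds than this note shows. Statements on the series, on what has been measured and on what is new or still open speak of the compounds shown alone.

In a functional assay on A2780cisR cells (Homo sapiens) for cytotoxicity, read by MTT assay, with a stated time of 72 h (on this read-out lower numbers stand for stronger inhibition and higher numbers for weaker inhibition), three compounds sharing one core have been measured: compound 1 (`O=C(CCCCCN(CC(=O)NC1CCCCC1)C(=O)c1ccccc1)NO`) gives 8210 nM, compound 2 (`O=C(CCCCCN(CC(=O)NC1CCCCC1)C(=O)c1cccc2ccccc12)NO`) gives 4120 nM and compound 3 (`Cc1cc(C)cc(C(=O)N(CCCCCC(=O)NO)CC(=O)NC2CCCCC2)c1`) gives 3810 nM. Among the measured compounds shown here, compound 1 carries the highest of these numbers, but only one of its two steps clears the scatter. The data show a 2.0-fold lower number from compound 1 to compound 2 (0.30 log units; within the scatter) and a 2.2-fold lower number from compound 1 to compound 3 (0.33 log units; beyond the scatter). The remaining comparison shows a 1.1-fold lower number from compound 2 to compound 3 (0.03 log units; within the scatter).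

Compound 4 (`CC(C)(C)NC(=O)CN(CCCCCC(=O)NO)C(=O)c1ccccc1`) has not yet been measured. It differs from compound 1 at another place: tert-butyl in place of cyclohexyl on an amide-type nitrogen. In words, tert-butyl stands in place of cyclohexyl on an amide-type nitrogen. For the measured compounds named here, no measured step changes that group, since all three replace the group on a carbonyl carbon. They therefore bear on the new change only indirectly, showing how little these three compounds have moved so far, with a 2.2-fold lower number from compound 1 to compound 3 (0.33 log units; beyond the scatter) as the largest step. On that thin evidence, no step beyond the scatter is expected in this assay, and no direction can be favoured with confidence. The estimated step is a 1.1-fold higher number from compound 1 to compound 4 (0.04 log units; within the scatter). For compound 4 the expected value is 9000 nM, with an estimated range of 4000 nM to 20000 nM.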

Compound 4, half-maximal inhibitory concentration: 42400 nM
Beside the measured number, compound 4's estimate is 4.7-fold (0.67 log units) below it; measured number outside the range, above it.
By their numbers in this assay, from the lowest: compounds 3, 2 and 1 (each within the scatter of the next, the first and the last beyond it); then compound 4.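

In this assay, among the compounds shown here, the change on the amide-type nitrogen gives a 5.2-fold higher number from compound 1 to compound 4 (0.71 log units; beyond the scatter) and is the first step in this set to reach a higher number, whereas the largest change on a carbonyl carbon gives a 2.2-fold lower number from compound 1 to compound 3 (0.33 log units; beyond the scatter) in the other direction. The earlier compounds shown here all kept cyclohexyl, so they could not show that this position matters: with phenyl held on the carbonyl carbon, tert-butyl, with four carbons and no ring, does not stand in for cyclohexyl, with six carbons in a six-membered ring, without a step beyond the scatter. No measurement shown here accounts for the rise in the number at this position.

The compounds shown leave open whether the step goes with the ring or with the carbon count, and a cyclopentyl or an open n-hexyl chain on the same nitrogen would help to separate the two. They also leave open whether tert-butyl brings a step of similar size when naphthalen-1-yl or 3,5-dimethylphenyl stands on the carbonyl carbon.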